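This account rests on a few compounds, and the source may have more. Where it says the series, first, only, none or still open, it means among the compounds named here.

Compound 2 `CCc1ccccc1[C@H]1[C@@H](OCc2cc(C(F)(F)F)cnc2OC)[C@H](C(C)(C)C)[C@@H](C(=O)O)N1C(=O)[C@@H]1CCCCO1` gives 48 nM in an assay on cells with Cystic fibrosis transmembrane conductance regulator variant F508del (Homo sapiens) as the target, read by voltage clamp, with a stated time of 24 h, in the presence of a further agent that is not named here (on this read-out higher numbers stand for an effect only at larger amounts of compound and lower numbers for an effect already at smaller amounts), and stands alongside compound 1 `COc1ncc(C(F)(F)F)cc1CO[C@H]1[C@H](C(C)(C)C)[C@@H](C(=O)O)N(C(=O)[C@@H]2CCCCO2)[C@H]1c1ccccc1C(C)C`, which gives 35 nM in this assay; a 1.4-fold higher number from compound 1 to compound 2 (0.14 log units; within the scatter). Compound 3 `COc1ncc(C(F)(F)F)cc1CO[C@H]1[C@H](C(C)(C)C)[C@@H](C(=O)O)N(C(=O)[C@@H]2CCCCO2)[C@H]1c1ccccc1CC(C)C` differs from compound 2 by isopropyl in place of methyl on a saturated chain carbon bound to an aromatic carbon. Within the data shown here, the only measured step touches the same place but removes rather than adds carbon, and it lies within the scatter; whether a larger group behaves alike is untested. A step of about a 1.1-fold higher number from compound 2 to compound 3 (0.06 log units; within the scatter) is therefore expected in this assay, without clear direction. Compound 3 is estimated at 55 nM in this assay, with a range of 20 nM to 150 nM.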

Compound 3, half-maximal effective concentration: 52 nM
Estimate against measurement, compound 3: 1.1-fold (0.02 log units) above; the measured number falls inside the stated range.
By their numbers in this assay, from the lowest: compounds 1, 2 and 3 (each within the scatter of the next).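

In this assay, the change from ethyl to isobutyl, read as isopropyl in place of methyl on a saturated chain carbon bound to an aromatic carbon, gives a 1.1-fold higher number from compound 2 to compound 3 (0.03 log units; within the scatter). Isobutyl in place of isopropyl on an aromatic carbon gives a 1.5-fold higher number from compound 1 to compound 3 (0.17 log units; within the scatter), so a larger group now joins the earlier removal of carbon, and ethyl, isopropyl and isobutyl all lie within the scatter of one another. Nothing available explains this flat result.

Going by these compounds, whether a longer chain, a primary amine or a carboxylic acid at this place would give a step beyond the scatter remains open.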